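Swapping propargyl for hydrogen on an amide-type nitrogen

The source may report more compounds than this note shows. Statements on the series, on what has been measured and on what is new or still open speak of the compounds shown alone.

Measured in a functional assay on DU-145 cells (Homo sapiens) for inhibition, read by WST assay, with a stated time of 48 h; a higher number here means a weaker inhibitor of growth, a lower number a stronger inhibitor of growth:
compound 1 `C=C(C)C(=O)N(Cc1cccc(Br)c1)C(=O)/C=C/c1cc(OC)c(OC)c(OC)c1`: 5700 nM
compound 2 `C#CCN(C(=O)/C=C/c1cc(OC)c(OC)c(OC)c1)C(=O)C(=C)C`: 2300 nM

Of these two, compound 2 holds the lower number, 2300 nM, which makes it the stronger inhibitor of growth. The next compound, compound 3 `C=C(C)C(=O)NC(=O)/C=C/c1cc(OC)c(OC)c(OC)c1`, has not yet been measured. It carries hydrogen in place of propargyl on an amide-type nitrogen. Going by the values given here, only one measured step concerns the group on that nitrogen: a 2.5-fold lower number from compound 1 to compound 2 (0.39 log units; beyond the scatter). Among the compounds with values here, that step is modest and involves a different pair of groups, and no measured compound has hydrogen there. A large change is therefore not expected in this assay, and the direction stays uncertain, with a slight lean towards a higher number. The expected step is small: a 1.3-fold higher number from compound 2 to compound 3 (0.12 log units; within the scatter). For compound 3 the estimated value is 3000 nM, with an expected range from 1000 nM to 9000 nM.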

Compound 3, concentration for 50% growth inhibition: 8600 nM
Compound 3: middle estimate off by 2.9-fold (0.46 log units), on the low side; measured number inside the range.
By their numbers in this assay, from the lowest: compound 2; then compounds 1 and 3 (each within the scatter of the next).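

Replacing the propargyl group on the nitrogen with hydrogen gives a 3.7-fold higher number from compound 2 to compound 3 (0.57 log units; beyond the scatter) in this assay and so shows that the group on this nitrogen can matter for growth inhibition. Having a group there is not enough on its own: going from 3-bromobenzyl to hydrogen gives a 1.5-fold higher number from compound 1 to compound 3 (0.18 log units; within the scatter) and leaves those two compounds indistinguishable, so propargyl is the only one of the three groups that stands clear of hydrogen. No measurement at hand explains this difference.

As far as these compounds go, it remains open whether a plain propyl chain, with three carbons but no triple bond, would behave like propargyl or like hydrogen. From the compounds shown here alone, it is equally open how a methyl group or a longer chain ending in a triple bond would fare on this nitrogen.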